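The source may report more compounds than this note shows. Statements on the series, on what has been measured and on what is new or still open speak of the compounds shown alone.

Measured compounds:

Compound 1, `CC(O)(CSc1ccc(C(F)(F)F)cc1)C(=O)Nc1cccc(S(F)(F)(F)(F)F)c1`, gives 26900 nM in a functional assay on CWR22R cells (Homo sapiens) for antiproliferative activity, read by propidium iodide staining, with a stated time of 96 h; a lower number here means a stronger inhibitor, a higher number a weaker inhibitor.
Compound 2, `CC(O)(CSc1ccc(OC(F)(F)F)cc1)C(=O)Nc1cccc(S(F)(F)(F)(F)F)c1`, gives 17000 nM in this assay.
Compound 3, `CC(O)(COc1ccccc1C(F)(F)F)C(=O)Nc1cccc(S(F)(F)(F)(F)F)c1`, gives 34900 nM in this assay.

Compound 1 and compound 2 share one core and differ in a single place: trifluoromethoxy in place of trifluoromethyl on an aromatic carbon. That change made a step of a 1.6-fold lower number from compound 1 to compound 2 (0.20 log units; within the scatter), so the two numbers cannot be told apart with confidence.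

Compound 3 has a different core. How it differs from compound 1 is not broken down here. Its number is the highest of the three measured, and its gap to compound 2 lies beyond the usual scatter, while its gap to compound 1 lies within it.

Compound 4, `CC(O)(COc1ccccc1OC(F)(F)F)C(=O)Nc1cccc(S(F)(F)(F)(F)F)c1`, has not been measured. It stands to compound 3 as compound 2 stands to compound 1: trifluoromethoxy in place of trifluoromethyl on an aromatic carbon. The surroundings are not identical, though. In the measured pair the group sits para to a large group, whereas in compound 4 it sits ortho to a large group, so this is the same kind of change rather than the same change.

On that basis a small step is expected, of the order already seen between compound 1 and compound 2. The expected step is a 1.4-fold lower number from compound 3 to compound 4 (0.14 log units; within the scatter). Compound 4 is therefore estimated at 25000 nM in this assay, with a likely range from 12000 nM to 50000 nM.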

Compound 4, half-maximal inhibitory concentration: 30000 nM
Beside the measured number, compound 4's estimate is 1.2-fold (0.08 log units) below it, within the range that was stated.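

Trifluoromethoxy in place of trifluoromethyl, tested in this assay on a second core, gave a 1.2-fold lower number from compound 3 to compound 4 (0.07 log units; within the scatter), so this pair of numbers cannot be told apart with confidence. The size of this step agrees with that of the earlier step on the first core: the same change on two cores in this assay, a 1.6-fold lower number (0.20 log units; within the scatter) from compound 1 to compound 2 and a 1.2-fold lower number (0.07 log units; within the scatter) from compound 3 to compound 4, 1.4-fold (0.13 log units) apart, within the scatter of two such steps. This shows that the change behaved alike on the two cores shown, with neither step large enough to stand out from ordinary repeat-to-repeat variation, but it does not show that the change has a real effect on either core, and two pairs of compounds are too few to set a rule for the whole series.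

The compounds shown leave open whether a group of a different kind at this place on the aromatic ring, such as an amine or a carboxylic acid, would produce a step beyond the scatter, rather than the small steps seen with these two closely related fluorinated groups. They also leave open whether trifluoromethoxy and trifluoromethyl would still give numbers this close on a core carrying a longer chain.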